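This account rests on a few compounds, and the source may have more. Where it says the series, first, only, none or still open, it means among the compounds named here.

Compound 1, `CC(C)CC(=O)O[C@@H]1OC=C(CO[C@@H]2O[C@H](CO)[C@@H](O)[C@H](O)[C@H]2OC(=O)/C=C/c2ccc(O)cc2)[C@H]2CC[C@](O)(CO)[C@@H]12`, was studied in a functional assay on SK-MEL-2 cells (Homo sapiens) for cytotoxicity, read by sulforhodamine B assay, with a stated time of 48 h; a lower number here means a stronger inhibitor, a higher number a weaker inhibitor. In this assay compound 1 reaches only a limit, > 10000 nM. Its companion compound 2, `CC(C)CC(=O)O[C@@H]1OC=C(CO[C@@H]2O[C@H](CO)[C@@H](O)[C@H](O)[C@H]2OC(=O)/C=C\c2ccc(O)cc2)[C@H]2CC[C@](O)(CO)[C@@H]12`, has the same atoms and bonds and differs only in how one double bond is drawn; in this assay compound 2 gives 8400 nM. Among the compounds with values here, the only measured step, an at least 1.1-fold lower number from compound 1 to compound 2 (0.07 log units; that floor lies within the scatter), stays within the usual scatter. Compound 1 therefore stands at the top of the numbers shown, marked by the limit of > 10000 nM in this assay, at which 1 of the 2 values shown sits, and the pair differs only as the fact that compounds 1 and 2 differ only in the configuration as drawn states, so that the step carries no information about any other change.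

Compound 3, `CCC(C)C(=O)O[C@@H]1OC=C(CO[C@@H]2O[C@H](CO)[C@@H](O)[C@H](O)[C@H]2OC(=O)/C=C/c2ccc(O)cc2)[C@H]2CC[C@](O)(CO)[C@@H]12`, has not yet been measured. It differs from compound 1 in one place: sec-butyl in place of isobutyl on a carbonyl carbon. Within the data shown here, no measured step touches this part of the molecule; the one step available, an at least 1.1-fold lower number from compound 1 to compound 2 (0.07 log units; that floor lies within the scatter), concerns a drawn double bond and is within the scatter. The chemist therefore expects no step beyond the scatter, a step that the limit leaves unreadable from compound 1 to compound 3. For compound 3 the estimate in this assay is 12000 nM, with a range from 5000 nM to 30000 nM, and a real chance that only a limit is reported.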

Compound 3, half-maximal inhibitory concentration: 1400 nM
Estimate against measurement, compound 3: 8.6-fold (0.93 log units) above; measured number outside the range, below it.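

In this assay, replacing isobutyl with sec-butyl on a carbonyl carbon gives an at least 7.1-fold lower number from compound 1 to compound 3 (0.85 log units; beyond the scatter), so this position responds beyond the scatter even though the two groups hold the same atoms, joined differently. The earlier step could not show this, as it concerned another part of the molecule and stayed within the scatter: the fact that compounds 1 and 2 differ only in the configuration as drawn. The step gives only a floor for the size of the change, as compound 1 stands at a limit and not at a number: the limit of > 10000 nM in this assay, at which 1 of the 3 values shown sits.

The compounds shown leave open whether the gain belongs to sec-butyl alone or extends to other groups at this carbonyl carbon, such as tert-butyl, a longer chain like n-hexyl, a phenyl ring or an amine. They also leave open whether sec-butyl would give a similar step on the shared core with the double bond drawn Z, as in compound 2, and how far the number would move with a measured value in place of the limit for compound 1.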